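The compounds below may be only part of what the source reports. "The series", "measured", "known", "first", "only" and "open" are said of these compounds alone.

Three compounds share one core and differ only in the group carried by the amine nitrogen in the ring. In an assay on isolated protein for inhibition of Fatty-acid amide hydrolase 1 (Homo sapiens) (on this read-out higher numbers stand for weaker inhibition and lower numbers for stronger inhibition), compound 1 `CC(C)(C)CC(=O)N1CCC(CCCC(=O)c2ncco2)CC1` gives 90 nM, compound 2 `CC(C)S(=O)(=O)N1CCC(CCCC(=O)c2ncco2)CC1` gives 140 nM, and compound 3 `O=C(CCCC1CCN(Cc2ccccc2Cl)CC1)c1ncco1` gives 260 nM. Compound 3 thus has the highest of the three numbers: the step of a 2.9-fold higher number from compound 1 to compound 3 (0.46 log units; beyond the scatter) lies beyond the scatter, whereas a 1.9-fold higher number from compound 2 to compound 3 (0.27 log units; within the scatter) stays within it, so compound 3 and compound 2 cannot be told apart, and a 1.6-fold higher number from compound 1 to compound 2 (0.19 log units; within the scatter) is also within the scatter.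

Compound 4 `O=C(CCCC1CCN(Cc2cccc(Br)c2)CC1)c1ncco1` keeps the rest of compound 3 and changes (3-bromophenyl in place of 2-chlorophenyl on a saturated chain carbon bound to an amine nitrogen in a ring). Among the measured compounds shown here, no measured step touches only the substituent on this phenyl ring; each replaces the whole group on the ring nitrogen, and even those replacements give at most modest steps. A step within the scatter, in no particular direction, is therefore expected, because a 1.9-fold higher number from compound 2 to compound 3 (0.27 log units; within the scatter) and a 2.9-fold higher number from compound 1 to compound 3 (0.46 log units; beyond the scatter) bound how far such changes have moved this read-out. Compound 4 is expected at 260 nM in this assay, within 100 nM to 700 nM, an expected step of no change at the digits printed from compound 3 to compound 4 (within the scatter).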

Compound 4, half-maximal inhibitory concentration: 10 nM
Estimate against measurement, compound 4: 26-fold (1.41 log units) above; measured number outside the range, below it.
By their numbers in this assay, from the lowest: compound 4; then compounds 1, 2 and 3 (each within the scatter of the next, the first and the last beyond it).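

In this assay, replacing 2-chlorophenyl with 3-bromophenyl gives a 26-fold lower number from compound 3 to compound 4 (1.41 log units; beyond the scatter), so a change within the phenyl ring can matter far more here than the earlier swaps of the whole group on the ring nitrogen did. The 3-bromobenzyl group also outperforms the two non-benzyl groups, with a 14-fold lower number from compound 2 to compound 4 (1.15 log units; beyond the scatter) and a 9.0-fold lower number from compound 1 to compound 4 (0.95 log units; beyond the scatter), so a benzyl group is not tied to the weakest result in the set, as compound 3 alone had suggested. No measurement shown here explains this gain.

The halogen and its place on the ring change together, so the compounds shown cannot say which of the two drives the step. A 3-chlorobenzyl or 2-bromobenzyl group would separate them, and a plain benzyl group would show what either halogen adds.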